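From dithiocarbamate amines to a bromopropyl ether on one core

The source may report more compounds than this note shows. Statements on the series, on what has been measured and on what is new or still open speak of the compounds shown alone.

Of the compounds shown here, three sharing one core have been measured in a functional assay on MGC-803 cells (Homo sapiens) for inhibition, read by MTT assay, with a stated time of 48 h; on this read-out higher numbers stand for weaker inhibition and lower numbers for stronger inhibition. Compound 1 `COc1ccc(-c2coc3cc(OCCCSC(=S)N4CCCC4)ccc3c2=O)cc1` gives 40000 nM, compound 2 `COc1ccc(-c2coc3cc(OCCCSC(=S)N4CCN(c5ccccn5)CC4)ccc3c2=O)cc1` gives 42000 nM, and compound 3 `COc1ccc(-c2coc3cc(OCCCSC(=S)N4CCN(C)CC4)ccc3c2=O)cc1` gives 21900 nM. The step of a 1.1-fold higher number from compound 1 to compound 2 (0.02 log units; within the scatter) is within the scatter, as are a 1.8-fold lower number from compound 1 to compound 3 (0.26 log units; within the scatter) and a 1.9-fold lower number from compound 2 to compound 3 (0.28 log units; within the scatter), so compound 3 stands together with the other two rather than apart from them. Compound 4 `COc1ccc(-c2coc3cc(OCCCBr)ccc3c2=O)cc1` differs from compound 3 by one bromine atom in place of a group of 10 heavy atoms (6 carbon, 2 nitrogen, 2 sulfur; one six-membered non-aromatic ring with 2 hetero atoms), on a saturated chain carbon, three bonds along the chain from an oxygen on an aromatic ring. Among the measured compounds shown here, none of the measured steps bears on this change: each only swaps one amine on the thiocarbonyl carbon for another, and none moved the number beyond the scatter. Compound 4 is therefore estimated at 35000 nM, between 10000 nM and 120000 nM, an expected step of a 1.6-fold higher number from compound 3 to compound 4 (0.20 log units; within the scatter) that itself lies within the scatter.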

Compound 4, half-maximal inhibitory concentration: 64900 nM
Estimate against measurement, compound 4: 1.9-fold (0.27 log units) below; measured number inside the range.
By their numbers in this assay, from the lowest: compounds 3, 1, 2 and 4 (each within the scatter of the next, the first and the last beyond it).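

Among the compounds shown here, putting bromo on the saturated chain carbon, three bonds along the chain from an oxygen on an aromatic ring, gives the first step to pass beyond the scatter, though only a modest one (a 3.0-fold higher number from compound 3 to compound 4 (0.47 log units; beyond the scatter)). The same exchange read against the pyrrolidin-1-yl compound stays within the scatter (a 1.6-fold higher number from compound 1 to compound 4 (0.21 log units; within the scatter)), so the separation holds against only one of these two amine-bearing compounds. No available evidence accounts for either step. On these data alone, whether a simple amine, a hydroxyl or a longer chain at this carbon would read differently remains open.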